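This account rests on a few compounds, and the source may have more. Where it says the series, first, only, none or still open, it means among the compounds named here.

Measured compounds:
compound 1, `COc1cc(NC(=O)Nc2cc(Nc3cccc(C(C)(C)C)c3)ncn2)cc(OC)c1` — 68%
compound 2, `COc1cc(NC(=O)Nc2cc(Nc3ccc(F)c(Cl)c3)ncn2)cc(OC)c1` — 77.5%
compound 3, `COc1cc(NC(=O)Nc2cc(Nc3cc(F)ccc3OC)ncn2)cc(OC)c1` — 59.5%

All three numbers come from a functional assay on PC-9 cells (Homo sapiens) for inhibition, read by MTT assay, with a stated time of 48 h, tested at 10 uM; a lower number here means less inhibition, a higher number more inhibition at the concentration tested (going by the name of the read-out). Compound 3 stands at the lowest of the three numbers: the gap to compound 1, a number 8.5 percentage points lower from compound 1 to compound 3 (within the scatter), is within the scatter, whereas the gap to compound 2, a number 18 percentage points lower from compound 2 to compound 3 (beyond the scatter), is beyond it. Only the group on the nitrogen on the aromatic ring is varied across the set.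

Compound 4, `CCc1cccc(Nc2cc(NC(=O)Nc3cc(OC)cc(OC)c3)ncn2)c1`, has not yet been run in this assay. Its change from compound 3 is 3-ethylphenyl in place of 5-fluoro-2-methoxyphenyl on a nitrogen on an aromatic ring. For the measured compounds named here, two measured steps bear on it. The step of a number 8.5 percentage points lower from compound 1 to compound 3 (within the scatter) replaces one 3-alkyl-substituted phenyl, the 3-(tert-butyl)phenyl, with the 5-fluoro-2-methoxyphenyl and is within the scatter; the step of a number 18 percentage points lower from compound 2 to compound 3 (beyond the scatter) is modest and beyond the scatter. Compound 4 carries 3-ethylphenyl, so the change from compound 3 reverses the direction of the first of these steps toward the pattern of compound 1. A small rise is therefore expected for compound 4, estimated as a number 7.5 percentage points higher from compound 3 to compound 4 (within the scatter), which may not clear the scatter. The value of compound 4 in this assay is expected to be about 67%, within the range 52% to 82%.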

Compound 4, a percentage reported as inhibition, at one concentration (the size of the read-out at that concentration, not a potency): 82.1%
Compound 4: the middle estimate sits 15.1 percentage points below what was measured; measured number above the stated range.
By their numbers in this assay, from the lowest: compounds 3, 1, 2 and 4 (each within the scatter of the next, the first and the last beyond it).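

On the nitrogen on an aromatic ring, the choice of alkyl group matters in this assay: ethyl in place of tert-butyl gives a number 14.1 percentage points higher from compound 1 to compound 4 (beyond the scatter) and separates two groups that the earlier set could not compare, since it held only one alkyl-substituted phenyl. A halogen on this phenyl ring is not needed to reach the level of compound 2, as a number 4.6 percentage points higher from compound 2 to compound 4 (within the scatter) shows for the halogen-free 3-ethylphenyl, while a number 22.6 percentage points higher from compound 3 to compound 4 (beyond the scatter) places compound 3 apart from compound 4 as well as from compound 2, so the 5-fluoro-2-methoxyphenyl group goes against any simple link between halogen and a high reading. No measurement shown here accounts for any of these steps.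

Going by these compounds, whether the change from tert-butyl to ethyl carries on to methyl, or reverses with a propyl or longer chain, remains open, as does the outcome with an amine or a carboxylic acid on this phenyl ring. On these data alone, each reading comes from a single concentration, so how the effects of compound 2, compound 4 and the others compare at any other concentration also remains open.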